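The compounds below may be only part of what the source reports. "The series", "measured", "known", "first", "only" and "open" are said of these compounds alone.

Measured so far:
compound 1 `Cn1nc(C(=O)O)c2ccc(N3C(=O)CCc4cc(OCc5c(-c6c(Cl)cccc6Cl)noc5C5CC5)ccc43)cc21`: > 100%
compound 2 `O=C1CCc2cc(OCc3c(-c4c(Cl)cccc4Cl)noc3C3CC3)ccc2N1c1ncc(O)cc1F`: > 100%

Both entries in an assay on isolated protein for agonist activity at Bile acid receptor (Homo sapiens), read by AlphaScreen, with a stated time of 1 h (on this read-out lower numbers stand for smaller maximal responses and higher numbers for larger maximal responses), are limits of the assay rather than numbers. Compound 1 is reported only as the limit > 100%. Compound 2 is likewise reported only as the limit > 100% in this assay. Among the measured compounds shown here, compound 2 therefore stands at the ceiling of the read-out, together with compound 1 (the limit of > 100% in this assay, at which 2 of the 2 values shown sit); no step between measured compounds can be sized.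

Compound 3 `O=C(O)c1ccc(N2C(=O)CCc3cc(OCc4c(-c5c(Cl)cccc5Cl)noc4C4CC4)ccc32)cc1O` differs from compound 2 by a group of 10 heavy atoms (7 carbon, 3 oxygen; one six-membered aromatic ring of carbon only) in place of a group of 8 heavy atoms (5 carbon, 1 nitrogen, 1 oxygen, 1 fluorine; one six-membered aromatic ring with 1 hetero atom), on an amide-type nitrogen in a ring. No move beyond the scatter is expected in this assay, the estimated step being a step that the limit leaves unreadable from compound 2 to compound 3. Compound 3 is expected near 110%, range 85% to 140%, most likely again reported as a limit.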

Compound 3, largest response reached (Emax), in percent of the reference or control that the assay uses: > 100%
Compound 3 gave a limit, no number (the forecaster's own chance of this, stated with the estimate: 70%); the middle value does not contradict the limit.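

No step can be read from compound 2 to compound 3 in this assay, since both results are limits rather than numbers: the limit of > 100% in this assay, at which 3 of the 3 values shown sit.

Left open is how compound 1, compound 2 and compound 3 rank, and whether the 4-carboxy-3-hydroxyphenyl group changes the maximal response at all.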